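Chloro to hydroxy on the shared core

The source may hold more compounds than are shown below. What is called first, only, known or untested is meant among the compounds shown, and "the series" means these compounds.

In a functional assay (a lower number here means a stronger inhibitor, a higher number a weaker inhibitor), compound 1 `CC(C)=CCOc1cc(O)c2c(c1)OC(c1ccccc1Cl)CC2=O` gives 4270 nM and compound 2 `CC(C)=CCOc1cc(O)c2c(c1)OC(c1ccc(Cl)cc1)CC2=O` gives 7020 nM, so compound 2 stands within the scatter of compound 1. Compound 3 `CC(C)=CCOc1cc(O)c2c(c1)OC(c1ccc(O)cc1)CC2=O` has hydroxy in place of chloro on an aromatic carbon, para to a large group: hydroxy in place of chloro on an aromatic carbon. For the measured compounds named here, the sole measured step, a 1.6-fold higher number from compound 1 to compound 2 (0.22 log units; within the scatter), exchanges 2-chlorophenyl for 4-chlorophenyl and keeps the chloro, so it bears only indirectly and gives no direction. No step beyond the scatter is expected, and the estimated step is a 1.2-fold lower number from compound 2 to compound 3 (0.07 log units; within the scatter). For compound 3 the estimate is 6000 nM, with an expected range of 1800 nM to 20000 nM.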

Compound 3, half-maximal inhibitory concentration: 5340 nM
Beside the measured number, compound 3's estimate is 1.1-fold (0.05 log units) above it, and the stated range covers the measured number.
By their numbers in this assay, from the lowest: compounds 1, 3 and 2 (each within the scatter of the next).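

Hydroxy in place of chloro on the aromatic carbon gives a 1.3-fold lower number from compound 2 to compound 3 (0.12 log units; within the scatter) in this assay, so this exchange, which enters a hydrogen-bond donor and acceptor, produces no readable difference. The 4-hydroxyphenyl group also stands level with 2-chlorophenyl, with a 1.3-fold higher number from compound 1 to compound 3 (0.10 log units; within the scatter). No supporting data bear on this result. As far as these compounds go, whether an amine, a carboxylic acid or a methoxy group in the same place would give a step beyond the scatter remains open. Also open, from the compounds shown here alone, is whether changes elsewhere on the shared core would move the number more than this one.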